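Changing the Group on the Carbonyl Carbon

The compounds below may be only part of what the source reports. "The series", "measured", "known", "first", "only" and "open" are said of these compounds alone.

In a functional assay on MGC-803 cells (Homo sapiens) for inhibition, read by MTT assay, with a stated time of 48 h (a higher number here means a weaker inhibitor, a lower number a stronger inhibitor), compound 1 (`COc1ccc(CN(C(C)=O)c2cc(OC)c(OC)c(OC)c2)cc1O`) gives 79 nM and compound 2 (`COc1ccc(CN(C(=O)/C=C/CBr)c2cc(OC)c(OC)c(OC)c2)cc1O`) gives 71 nM, so compound 2 stands level with compound 1 within the scatter. For the measured compounds named here, only one measured step bears on this place: a 1.1-fold lower number from compound 1 to compound 2 (0.05 log units; within the scatter), which put 3-bromoprop-1-en-1-yl in place of methyl on a carbonyl carbon and stayed within the scatter. Compound 3 (`COc1ccc(CN(C(=O)C[Se]C#N)c2cc(OC)c(OC)c(OC)c2)cc1O`) is changed at that same place: a group of 4 heavy atoms (2 carbon, 1 nitrogen, 1 selenium; no ring) in place of a group of 4 heavy atoms (3 carbon, 1 bromine; no ring), on a carbonyl carbon. Going by the values given here, no measured compound carries selenium, so that single small step is the only guide. No change beyond the scatter is therefore expected in this assay, and no direction can be argued from the data. The estimated change is a 1.2-fold lower number from compound 2 to compound 3 (0.07 log units; within the scatter). Compound 3 is expected at 60 nM, within an estimated range of 18 nM to 200 nM.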

Compound 3, half-maximal inhibitory concentration: 270 nM
Compound 3: middle estimate off by 4.5-fold (0.65 log units), on the low side; the whole stated range lies below it.
By their numbers in this assay, from the lowest: compounds 2 and 1 (each within the scatter of the next); then compound 3.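

The place on the carbonyl carbon, whose other neighbour is the amide-type nitrogen, turns out not to be indifferent to what it carries: in this assay, the selenium-bearing group gives a 3.8-fold higher number from compound 2 to compound 3 (0.58 log units; beyond the scatter). The same group also stands apart from the methyl of compound 1, with a 3.4-fold higher number from compound 1 to compound 3 (0.53 log units; beyond the scatter), so the level result for 3-bromoprop-1-en-1-yl and methyl does not extend to every group of this size at this place. Nothing measured on these compounds accounts for the loss.

The selenium, the nitrile and the loss of the double bond all change together here, and the compounds shown do not separate them. On these data alone, whether a sulfur atom in place of the selenium, or an amine on the same chain, would stay level with compound 1 remains open.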